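A few compounds are considered here, and "the series" means these few. Any claim that something is new, unique, unknown or untested is made for them only; others in the source may bear on it.

Series notes. Within the data shown here, compound 1 `CCCCCCCCCCn1cc(-c2nc3ccccc3cc2C)nn1` is the only member with a numerical result: in a functional assay on HeLa cells (Homo sapiens) for cytotoxicity, read by MTT assay, with a stated time of 24 h (a lower number here means a stronger inhibitor, a higher number a weaker inhibitor), compound 1 gives 28.2 ug/mL. Compound 2 `CCCCCCCCCCn1cc(-c2nc3ccccc3cc2CC)nn1` differs from it by methyl in place of hydrogen on a saturated chain carbon bound to an aromatic carbon. In this assay compound 2 returns > 100 ug/mL, which is a limit of the assay and not a number. The step of an at least 3.5-fold higher number from compound 1 to compound 2 (0.54 log units; beyond the scatter) is therefore at least modest and beyond the scatter. Compound 3 `CCc1cc2ccccc2nc1-c1cn(-c2ccc(F)cc2)nn1` rests on a different core, and the difference between the two cores is not broken down here. In this assay compound 3 also returns > 100 ug/mL, again a limit rather than a number. Compound 4 `CCCc1cc2ccccc2nc1-c1cn(-c2ccc(F)cc2)nn1`, not yet measured, differs from compound 3 by methyl in place of hydrogen on a saturated chain carbon, two bonds along the chain from an aromatic carbon. This is the same kind of change as that from compound 1 to compound 2, though the place differs: there the saturated chain carbon is bound to an aromatic carbon, here it is two bonds along the chain from an aromatic carbon. Because the limit of > 100 ug/mL in this assay, at which 2 of the 3 values shown sit, already holds compound 3, a second numerical step cannot be read off. The step that the limit leaves unreadable from compound 3 to compound 4 is expected to be flat or upward. Compound 4 is expected near 150 ug/mL in this assay, most probably again as a limit, between 60 ug/mL and 400 ug/mL.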

Compound 4, half-maximal inhibitory concentration: > 100 ug/mL
Compound 4: no number, only a limit; the forecaster's own chance of this, stated with the estimate: 80%; the middle value lies beyond the limit too.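

In this assay compound 4 returns > 100 ug/mL as a limit and not a number. Among these compounds, compound 3 also stands at a limit, so no step between compound 3 and compound 4 can be read: the limit of > 100 ug/mL in this assay, at which 3 of the 4 values shown sit.
The compounds shown leave open how far compound 3 and compound 4 lie past the limit, and whether the change from ethyl to propyl alters the result at all.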